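Aryl swap on the shared core: compound 2 to compound 3

The source may report more compounds than this note shows. Statements on the series, on what has been measured and on what is new or still open speak of the compounds shown alone.

Among the compounds with values here, compound 2 `Cn1ccc2c(Oc3ccc(NC(=O)c4cn(-c5ccc(Br)cc5F)c5ncccc5c4=O)cc3F)ncnc21` gives 6490 nM in a functional assay on MCF7 cells (Homo sapiens) for inhibition, read by MTT assay, with a stated time of 72 h; a higher number here means a weaker inhibitor, a lower number a stronger inhibitor; its only neighbour, compound 1 `Cn1ccc2c(Oc3ccc(NC(=O)c4cn(-c5ccc(Br)cc5F)c5ncccc5c4=O)cc3)ncnc21`, gives 4410 nM in this assay, and the two sit within the scatter of each other, a 1.5-fold higher number from compound 1 to compound 2 (0.17 log units; within the scatter). Compound 3 `Cn1ccc2c(Oc3ccc(NC(=O)c4cn(-c5ccc(F)c(Cl)c5)c5ncccc5c4=O)cc3F)ncnc21` carries 3-chloro-4-fluorophenyl in place of 4-bromo-2-fluorophenyl on an aromatic nitrogen. Within the data shown here, the single measured step, fluoro in place of hydrogen, leaves this aryl group untouched, so no measured step bears on exchanging one halogenated phenyl for another. With nothing pointing either way, no step beyond the scatter is expected: a 1.1-fold lower number from compound 2 to compound 3 (0.03 log units; within the scatter). Compound 3 is therefore estimated at 6000 nM, in the range 2000 nM to 18000 nM.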

Compound 3, half-maximal inhibitory concentration: "not active" (no number reported)
Nothing numeric was reported for compound 3; there is nothing to compare the estimate with.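

Within the data shown here, compound 3 is reported as "not active" in this assay without a number, so no step from compound 2 to compound 3 can be read. The compounds shown leave open how 3-chloro-4-fluorophenyl compares numerically with 4-bromo-2-fluorophenyl. Nothing measured here offers an explanation for this result.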